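Cyclohexyl to benzyl on the ring nitrogen: second occurrence

The compounds below may be only part of what the source reports. "The series", "measured", "known", "first", "only" and "open" are said of these compounds alone.

The series rests on two cores. Compound 1 `O=Cc1ccc(-c2cn3ccnc3c(-c3ccc4ncn(C5CCCCC5)c4c3)n2)cc1` carries a cyclohexyl on the ring nitrogen and in a functional assay on SNB-75 cells (Homo sapiens) for inhibition, read by sulforhodamine B assay, with a stated time of 48 h, tested at 10 uM (on this read-out lower numbers stand for less inhibition and higher numbers for more inhibition at the one concentration tested (going by the name of the read-out)), compound 1 gives 21.4%. Compound 2 `O=Cc1ccc(-c2cn3ccnc3c(-c3ccc4ncn(Cc5ccccc5)c4c3)n2)cc1` differs from compound 1 by benzyl in place of cyclohexyl on an aromatic nitrogen; in this assay compound 2 gives 21.4%, so that the step of no change at the digits printed from compound 1 to compound 2 (within the scatter). Compound 3 `c1cn2cc(-c3ccc4c(c3)ncn4C3CCCCC3)nc(-c3ccc4ncn(C5CCCCC5)c4c3)c2n1` has a different core; the difference between the two cores is not broken down here. In this assay compound 3 gives 24.8%, which lies within the scatter of the values of compound 1 and compound 2.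

Compound 4 `c1ccc(Cn2cnc3ccc(-c4nc(-c5ccc6c(c5)ncn6C5CCCCC5)cn5ccnc45)cc32)cc1` is not yet measured. Compound 4 differs from compound 3 by benzyl in place of cyclohexyl on an aromatic nitrogen, the same change as that from compound 1 to compound 2, made at a place described in the same words. Because the step of no change at the digits printed from compound 1 to compound 2 (within the scatter), the expected step of a number 0.8 percentage points lower from compound 3 to compound 4 (within the scatter) is set to be of the same kind, that is, no movement beyond the scatter. On that basis compound 4 is estimated at 24% in this assay, with a likely range from 14% to 34%.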

Compound 4, a percentage reported as inhibition, at one concentration (the size of the read-out at that concentration, not a potency): -67.4%
The estimate for compound 4 lay 91.4 percentage points above the measured number; the whole stated range lies above it.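

On the core of compound 3, benzyl in place of cyclohexyl on an aromatic nitrogen gives a number 92.2 percentage points lower from compound 3 to compound 4 (beyond the scatter), so in this assay this change does not carry over from one core to the other as a single effect: the same change on two cores in this assay, no change at the digits printed (within the scatter) from compound 1 to compound 2 and a number 92.2 percentage points lower (beyond the scatter) from compound 3 to compound 4, 92.2 percentage points apart, beyond the scatter of two such steps. The result on the core of compound 1 is therefore no guide to the result on the core of compound 3, and the reverse also holds. Within the data shown here, with only one pair per core, read at one concentration in one assay, the data do not show what in the core of compound 3 separates it from the core of compound 1, nor how the change would behave on any further core.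

Still open, going by these compounds, is how other groups on this ring nitrogen, such as methyl, phenethyl or a longer chain ending in an amine, would fare on each core. Also open, on these data alone, is whether replacing the cyclohexyl that compound 4 still carries with benzyl would move the number again.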